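The source may report more compounds than this note shows. Statements on the series, on what has been measured and on what is new or still open speak of the compounds shown alone.

Working notes on the series. In a physicochemical assay for solubility, read by spectrophotometry, in phosphate buffer, with a stated time of 18 h, at pH 7.4 (on this read-out higher numbers stand for higher solubility and lower numbers for lower solubility), compound 1 `Cc1cccc(-c2nc3c(c(C)nn3-c3ccccc3)c(-c3ccccc3O)c2C#N)c1` gives 42000 nM and compound 2 `Cc1ccccc1-c1nc2c(c(C)nn2-c2ccccc2)c(-c2ccccc2O)c1C#N` gives 21000 nM while compound 3 `Cc1nn(-c2ccccc2)c2nc(-c3ccc(F)cc3)c(C#N)c(-c3ccccc3O)c12` gives 6000 nM on the shared core, each with a different substituted phenyl group. The steps of a 3.5-fold lower number from compound 2 to compound 3 (0.54 log units; beyond the scatter) and a 7.0-fold lower number from compound 1 to compound 3 (0.85 log units; beyond the scatter) both lie beyond the scatter and leave compound 3 lowest of the three. The step of a 2.0-fold lower number from compound 1 to compound 2 (0.30 log units; within the scatter) stays within the scatter, so the two methylphenyl compounds are not told apart.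

Compound 4 `Cc1nn(-c2ccccc2)c2nc(-c3ccc([N+](=O)[O-])cc3)c(C#N)c(-c3ccccc3O)c12` has nitro in place of fluoro on an aromatic carbon para to a large group, the difference from compound 3 being nitro in place of fluoro on an aromatic carbon in full. For the measured compounds named here, no measured compound carries nitro, so the data do not fix the direction of the step. Going by the values given here, the only relevant evidence is the pair of changes at this same phenyl group, a 3.5-fold lower number from compound 2 to compound 3 (0.54 log units; beyond the scatter) and a 7.0-fold lower number from compound 1 to compound 3 (0.85 log units; beyond the scatter) and both were modest. A modest step is therefore expected in this assay with a tentative lean towards lower numbers. The estimated step is a 2.4-fold lower number from compound 3 to compound 4 (0.38 log units; beyond the scatter) with no change still possible. Compound 4 is expected at 2500 nM with an estimated range from 700 nM to 9000 nM on this reading.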

Compound 4, solubility: 6000 nM
Beside the measured number, compound 4's estimate is 2.4-fold (0.38 log units) below it; measured number inside the range.
By their numbers in this assay, from the lowest: compounds 3 and 4 (each within the scatter of the next); then compounds 2 and 1 (each within the scatter of the next).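

In this assay, nitro in place of fluoro on an aromatic carbon para to a large group gives no change at the digits printed from compound 3 to compound 4 (within the scatter), so this change does not separate the two groups, although nitro enters with 3 heavy atoms and 2 hydrogen-bond acceptors where fluoro leaves with 1 heavy atom and 0 hydrogen-bond acceptors. The 4-nitrophenyl group also stands apart from both methylphenyl groups, with a 3.5-fold lower number from compound 2 to compound 4 (0.54 log units; beyond the scatter) and a 7.0-fold lower number from compound 1 to compound 4 (0.85 log units; beyond the scatter), so among these four compounds the 4-fluorophenyl and 4-nitrophenyl compounds both lie below the two methylphenyl compounds, and none of the four goes against this. Nothing available on these compounds accounts for this result.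

Two substituents on one aromatic carbon cannot show whether the insensitivity extends to other groups there, such as an amine, a carboxylic acid or a longer alkyl chain. As far as these compounds go, it also remains open where a 4-methylphenyl compound would fall, and so whether the separation from compounds 1 and 2 follows the place of the substituent or the identity of the group.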